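Aryl variation on the saturated ring carbon of the pyrazoline series

The compounds below may be only part of what the source reports. "The series", "measured", "known", "first", "only" and "open" are said of these compounds alone.

Measured so far in a functional assay on WM 266-4 cells (Homo sapiens) for antiproliferative activity, read by MTT assay, with a stated time of 24 h; on this read-out higher numbers stand for weaker inhibition of growth and lower numbers for stronger inhibition of growth:
compound 1 `Clc1cccc(C2CC(c3ccc4c(c3)OCCO4)=NN2c2ccccc2)c1` gives 1750 nM
compound 2 `c1ccc(N2N=C(c3ccc4c(c3)OCCO4)CC2c2cccc3ccccc23)cc1` gives > 100000 nM
compound 3 `Cc1ccc(C2CC(c3ccc4c(c3)OCCO4)=NN2c2ccccc2)cc1` gives 2530 nM

Compound 2 returns only a limit of this assay, (the limit of > 100000 nM in this assay, at which 1 of the 3 values shown sits), so no number is known for it. Of the two numbers that are known, compound 3 stands as the higher, with compound 1 nearest: a 1.4-fold higher number from compound 1 to compound 3 (0.16 log units; within the scatter). The other measured steps are large in the opposite sense, an at least 57-fold higher number from compound 1 to compound 2 (1.75 log units; beyond the scatter) and an at least 39-fold lower number from compound 2 to compound 3 (1.59 log units; beyond the scatter), and both carry naphthalen-1-yl, which is not involved in the step that follows.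

Compound 4 `Brc1ccc(C2CC(c3ccc4c(c3)OCCO4)=NN2c2ccccc2)cc1` differs from compound 3 by bromo in place of methyl on an aromatic carbon. The step that bears on it is the exchange of 3-chlorophenyl for 4-methylphenyl, a 1.4-fold higher number from compound 1 to compound 3 (0.16 log units; within the scatter), which stayed within the scatter; one single-atom aryl substituent was exchanged for another without a large change. The exchange of methyl for bromo on the same aromatic carbon is expected to behave likewise, with no step beyond the scatter in either direction.

Compound 4 is therefore estimated at 2000 nM, with a range from 800 nM to 5000 nM. The step this estimate means, a 1.3-fold lower number from compound 3 to compound 4 (0.10 log units; within the scatter), is expected to lie within the scatter.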

Compound 4, concentration for 50% growth inhibition: 3010 nM
Beside the measured number, compound 4's estimate is 1.5-fold (0.18 log units) below it; the measured number falls inside the stated range.
By their numbers in this assay, from the lowest: compounds 1, 3 and 4 (each within the scatter of the next). At a limit, above all of these: compound 2.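

In this assay, bromo in place of methyl on the aromatic carbon para to a large group gives a 1.2-fold higher number from compound 3 to compound 4 (0.08 log units; within the scatter), the first exchange shown that alters only the group at one place on this aryl ring, and it leaves the read-out within the scatter. The step of a 1.7-fold higher number from compound 1 to compound 4 (0.24 log units; within the scatter) also stays within the scatter, so 3-chlorophenyl, 4-methylphenyl and 4-bromophenyl on the saturated ring carbon are not separated by this read-out in compound 1, compound 3 and compound 4. The step of an at least 33-fold lower number from compound 2 to compound 4 (1.52 log units; beyond the scatter) leaves naphthalen-1-yl as the only exchange at that carbon shown here that goes beyond the scatter, and compound 2 stands at a limit: the limit of > 100000 nM in this assay, at which 1 of the 4 values shown sits.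

Within the data shown here, still open is whether an amine, a carboxylic acid or a longer chain such as butyl on the same aromatic carbon would also stay within the scatter, since methyl and bromo are the only groups compared there. Naphthalen-2-yl on the saturated ring carbon would help show whether the large step follows the second fused ring as such or its point of attachment.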